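Chlorine and fluorine trade places on the phenyl ring

The source may report more compounds than this note shows. Statements on the series, on what has been measured and on what is new or still open speak of the compounds shown alone.

In an ADME assay on Vero cells (Chlorocebus sabaeus) for cytotoxicity, read by resazurin assay, with a stated time of 72 h (a lower number here means a stronger inhibitor, a higher number a weaker inhibitor), compound 1 (`COc1ccc(C(=O)CCN2CCN(c3ccc(C(F)(F)F)cc3)CC2)cc1`) reads 135000 nM while compound 2 (`COc1ccc(C(=O)CCN2CCN(c3ccc(C(F)(F)F)cc3)CC2)cc1OC`) reads 243000 nM and compound 3 (`O=C(CCN1CCN(c2ccc(C(F)(F)F)cc2)CC1)c1ccc(F)c(Cl)c1`) reads 74500 nM on the same scale. Compound 3 stands level with one neighbour (a 1.8-fold lower number from compound 1 to compound 3 (0.26 log units; within the scatter)) and clear of the other (a 3.3-fold lower number from compound 2 to compound 3 (0.51 log units; beyond the scatter)). Compound 4 (`O=C(CCN1CCN(c2ccc(C(F)(F)F)cc2)CC1)c1ccc(Cl)c(F)c1`) has the same atoms joined differently (4-chloro-3-fluorophenyl in place of 3-chloro-4-fluorophenyl on a carbonyl carbon) with 4-chloro-3-fluorophenyl in place of 3-chloro-4-fluorophenyl on a carbonyl carbon. Within the data shown here, no measured step makes this swap. Adding one methoxy stayed small (a 1.8-fold higher number from compound 1 to compound 2 (0.26 log units; within the scatter)) and exchanging the whole group gave only a modest step (a 3.3-fold lower number from compound 2 to compound 3 (0.51 log units; beyond the scatter)). So no step beyond the scatter is expected in this assay and the estimated change is slight (a 1.1-fold higher number from compound 3 to compound 4 (0.03 log units; within the scatter)). Compound 4 is expected at 80000 nM within an estimated range of 40000 nM to 150000 nM in this assay.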

Compound 4, half-maximal inhibitory concentration: 74300 nM
Estimate against measurement, compound 4: 1.1-fold (0.03 log units) above; the range from low to high includes it.
By their numbers in this assay, from the lowest: compounds 4, 3, 1 and 2 (each within the scatter of the next, the first and the last beyond it).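

In this assay the exchange of chlorine and fluorine on the phenyl ring changes nothing that can be seen (a 1.0-fold lower number from compound 3 to compound 4 (0.00 log units; within the scatter)), so on this carbonyl carbon the read-out does not separate 4-chloro-3-fluorophenyl from 3-chloro-4-fluorophenyl. Compound 4 also matches compound 3 against the methoxy compounds: one step lies beyond the scatter (a 3.3-fold lower number from compound 2 to compound 4 (0.51 log units; beyond the scatter)), and the other lies within it (a 1.8-fold lower number from compound 1 to compound 4 (0.26 log units; within the scatter)). Nothing available explains this result. On these data alone, whether an amine or a nitrile on this phenyl ring would shift the reading remains open.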